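A Smaller Acetylated Ring on a Potent Inhibitor

The compounds below may be only part of what the source reports. "The series", "measured", "known", "first", "only" and "open" are said of these compounds alone.

Of the compounds shown here, two have so far been tested in an assay on cells for inhibition of cytochrome P450 11B2, mitochondrial (Homo sapiens), read by HTRF; on this read-out higher numbers stand for weaker inhibition and lower numbers for stronger inhibition. Compound 1 `Cc1cc(Cl)ccc1C(=O)N(C)c1cccnc1` is a simple amide joining two aromatic rings. In this assay compound 1 reaches only > 3000 nM, which is a limit of the assay rather than a measured number. Compound 2 `CC(=O)N1CCC(Oc2cncc(N3C(=O)c4ccc(Cl)cc4C3(C)C)c2)CC1` carries the shared core with a 1-acetylpiperidin-4-yl group on an oxygen on an aromatic ring, and in this assay compound 2 gives 4 nM. Going by the values given here, that is the only true number among the values shown; the other entry is a limit (the limit of > 3000 nM in this assay, at which 1 of the 2 values shown sits). Compound 3 `CC(=O)N1CC[C@@H](Oc2cncc(N3C(=O)c4ccc(Cl)cc4C3(C)C)c2)C1` differs from compound 2 in a single place: 1-acetylpyrrolidin-3-yl in place of 1-acetylpiperidin-4-yl on an oxygen on an aromatic ring. Among the compounds with values here, no measured pair of compounds differs in this way, so there is no direct guide to the size of the step. Exchanging a six-membered ring for a five-membered one, with the acetyl group kept, is a modest change, and the step from compound 2 to compound 3 is expected to be a 2.0-fold higher number from compound 2 to compound 3 (0.30 log units; within the scatter), within or close to the usual scatter. Compound 3 is therefore estimated at 8 nM, with a range from 2 nM to 40 nM.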

Compound 3, half-maximal inhibitory concentration: 11 nM
The estimate for compound 3 lay 1.4-fold (0.14 log units) below the measured number; the measured number falls inside the stated range.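

In this assay, putting 1-acetylpyrrolidin-3-yl in place of 1-acetylpiperidin-4-yl on an oxygen on an aromatic ring gives a 2.8-fold higher number from compound 2 to compound 3 (0.44 log units; beyond the scatter), the first sign that this position responds to a change in the ring that carries the acetyl group. The response is modest, and compound 3, with its five-membered ring, still gives 11 nM, so a six-membered ring is not essential at this position for a low number on this read-out. This is a single step between two compounds, and nothing shown explains the difference, since the data hold no measurement that bears on its cause.

The compounds shown leave open whether the acetyl group itself matters, as a plain amine or a carboxylic acid on the ring in its place could give a very different number. As far as these compounds go, compound 3 also has one defined stereocentre, so how the mirror-image form of the 1-acetylpyrrolidin-3-yl group would behave remains unknown, as does whether a four-membered azetidine ring carrying the same acetyl group would extend the trend or break it.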